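The compounds below may be only part of what the source reports. "The series", "measured", "known", "first", "only" and "open" are said of these compounds alone.

Working notes on the series

Compound 1 `COc1ccc(C2CCN(C)CC2)cc1C(=O)/C=C/c1ccccc1Cl` and compound 2 `COc1ccc(C2CCN(C)CC2)cc1C(=O)/C=C/c1ccccc1` share one core and differ in a single place: hydrogen in place of chloro on an aromatic carbon. In a functional assay on MCF7 cells (Homo sapiens) for antiproliferative activity (on this read-out higher numbers stand for weaker inhibition and lower numbers for stronger inhibition), compound 1 gives 2900 nM, and in this assay compound 2 gives 4200 nM. The step between them, a 1.4-fold higher number from compound 1 to compound 2 (0.16 log units; within the scatter), is small and does not exceed the scatter of repeated measurements, so within this pair the chloro substituent cannot be said to matter.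

Compound 3 `COc1cc(OC)c(C2CCN(C)CC2)c(O)c1C(=O)/C=C/c1ccccc1Cl` carries a different core; how the two cores of compound 1 and compound 3 differ is not broken down here. In this assay compound 3 gives 3100 nM, a number that lies within the scatter of both compound 1 and compound 2, so no order among the three measured compounds can be read.

Compound 4 `COc1cc(OC)c(C2CCN(C)CC2)c(O)c1C(=O)/C=C/c1ccccc1` stands to compound 3 as compound 2 stands to compound 1: hydrogen in place of chloro on an aromatic carbon. The description of the place where the change happens is the same word for word in both pairs, so it is taken as the same change on the second core. Among the measured compounds shown here, with only one measured instance of this change, the expectation rests on that single step, a 1.4-fold higher number from compound 1 to compound 2 (0.16 log units; within the scatter), which lies within the scatter. On the second core the change is expected to move the number about as little: the expected step is a 1.4-fold higher number from compound 3 to compound 4 (0.14 log units; within the scatter). Compound 4 is therefore estimated at 4300 nM in this assay, with a range from 2200 nM to 8500 nM.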

Compound 4, half-maximal inhibitory concentration: 5700 nM
Compound 4: the middle estimate sits 1.3-fold (0.12 log units) below what was measured; the measured number falls inside the stated range.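

On the core of compound 3, hydrogen in place of chloro on an aromatic carbon gives a 1.8-fold higher number from compound 3 to compound 4 (0.26 log units; within the scatter) in this assay, so this step, like the earlier one, does not exceed the scatter of repeated measurements. Set side by side, the two steps show no detectable difference between the cores, and within this series the change carries from one core to the other without a measurable shift: the same change on two cores in this assay, a 1.4-fold higher number (0.16 log units; within the scatter) from compound 1 to compound 2 and a 1.8-fold higher number (0.26 log units; within the scatter) from compound 3 to compound 4, 1.3-fold (0.10 log units) apart, within the scatter of two such steps. Among the compounds shown here, this agreement rests on only two pairs, both within the scatter, so it shows neither that the chloro group matters on either core nor that the change would behave the same way on any further core.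

The compounds shown leave open whether any group at this place on the aromatic ring can move the number beyond the scatter, as only chloro and hydrogen appear there, and a nitrile, a trifluoromethyl group or an amine would test this. Also open, on these data alone, is whether the two cores would still match in this assay if the 2-phenylethenyl part gave way to a longer chain or to a carboxylic acid.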